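Swapping a Fluorophenyl for a Thiophene on a Shared Core

A few compounds are considered here, and "the series" means these few. Any claim that something is new, unique, unknown or untested is made for them only; others in the source may bear on it.

Measured so far:
compound 1 `O=Cc1ccc(-c2cn3ccnc3c(-c3ccc4ncn(C5CCCCC5)c4c3)n2)cc1` gives 14.4%
compound 2 `Fc1ccc(-c2cn3ccnc3c(-c3ccc4ncn(C5CCCCC5)c4c3)n2)cc1` gives 14.2%

Both numbers come from a functional assay on SNB-19 cells (Homo sapiens) for inhibition, read by sulforhodamine B assay, with a stated time of 48 h, tested at 10 uM; a higher number here means more inhibition at the concentration tested (going by the name of the read-out), a lower number less inhibition. Among the measured compounds shown here, compound 2 and compound 1 lie within the scatter of each other, so neither can be called weaker or stronger; the single measured step, a number 0.2 percentage points lower from compound 1 to compound 2 (within the scatter), shows how little a change on that phenyl ring moved this assay.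

Compound 3 `c1cn2cc(-c3ccsc3)nc(-c3ccc4ncn(C5CCCCC5)c4c3)c2n1` differs from compound 2 by thiophen-3-yl in place of 4-fluorophenyl on an aromatic carbon. For the measured compounds named here, no measured step exchanges the whole ring at this place; the one known step only varied a group on it and stayed within the scatter, so it gives weak guidance. Without a precedent for the ring swap, the expectation for compound 3 is no step beyond the scatter, a number 0.2 percentage points lower from compound 2 to compound 3 (within the scatter). Compound 3 is therefore estimated at 14%, with a range from 0% to 35%.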

Compound 3, a percentage reported as inhibition, at one concentration (the size of the read-out at that concentration, not a potency): 0.39%
The estimate for compound 3 lay 13.6 percentage points above the measured number; the range from low to high includes it.
By their numbers in this assay, from the lowest: compound 3; then compounds 2 and 1 (each within the scatter of the next).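

In this assay, replacing the whole ring at this position does what varying a group on the phenyl ring did not: thiophen-3-yl in place of 4-fluorophenyl gives a number 13.8 percentage points lower from compound 2 to compound 3 (beyond the scatter) and thiophen-3-yl in place of 4-formylphenyl gives a number 14 percentage points lower from compound 1 to compound 3 (beyond the scatter) as the second step of this kind. The position is therefore not indifferent to what sits on it, although the two phenyl compounds showed no difference from each other and the whole range of numbers remains low. No measurement shown here accounts for this drop.

The change swaps a six-membered carbon ring for a five-membered ring with sulfur in one move, so the effects of ring size and of the hetero atom cannot be told apart. On these data alone, whether a pyridine ring, or a phenyl ring carrying an amine or a carboxylic acid, would keep or raise the number stays open.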